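A few compounds are considered here, and "the series" means these few. Any claim that something is new, unique, unknown or untested is made for them only; others in the source may bear on it.

Measured so far:
- compound 1, `CCc1cc(C)cc2nc(N3CCN(C)CC3)oc12`: 6.46
- compound 2, `Cc1cc(C)c2oc(N3CCN(C)CC3)nc2c1`: 6.32
- compound 3, `COc1ccc2oc(N3CCN(C)CC3)nc2c1`: 4.78

All three share one core and were tested in a functional assay on ileum (strain Hartley) for agonist activity at 5-hydroxytryptamine receptor 3A (Cavia porcellus); a lower number here means a less potent compound, a higher number a more potent compound, by a factor of ten per unit of this negative logarithm. Compound 1 and compound 2 differ only by a methyl on a saturated chain carbon bound to an aromatic carbon, and the change a number 0.14 log units lower from compound 1 to compound 2 (within the scatter) is within the scatter. Compound 3 stands lowest of the three: its nearest neighbour is compound 2, and the gap to compound 1 is wider still, both beyond the scatter.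

Compound 4, `CC(=O)c1ccc2oc(N3CCN(C)CC3)nc2c1`, has not yet been tested in this assay. It is compound 3 with acetyl in place of methoxy on an aromatic carbon. Going by the values given here, no measured step concerns this position or a change from methoxy to acetyl; the only measured step, removing a methyl, changed little. What remains is that compound 3 itself sits far below compound 1 and compound 2. Compound 4 is therefore expected to stay near compound 3, with a wide range: the estimated step of a number 0.22 log units higher from compound 3 to compound 4 (within the scatter) gives compound 4 an expected value of 5, between 4.3 and 5.9.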

Compound 4, negative logarithm of the half-maximal effective concentration: < 4
Compound 4 was reported as a limit; the forecaster's own chance of this, stated with the estimate: 10%; at least 1.00 log units between middle value and limit.
By their numbers in this assay, from the lowest: compound 3; then compounds 2 and 1 (each within the scatter of the next). At a limit, below all of these: compound 4.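

In this assay compound 4 is reported only as a limit, < 4. Even so, the change can be read as a direction: acetyl in place of methoxy on this aromatic carbon gives a number at least 0.78 log units lower from compound 3 to compound 4 (beyond the scatter), the first step shown here that lies beyond the scatter, so what sits at this position clearly matters for the read-out, and methoxy is the better of the two groups tested there. The true size of the drop cannot be read, and the step gives only its minimum, set by this: the limit of < 4 in this assay, at which 1 of the 4 values shown sits.

Only methoxy and acetyl are shown on this carbon, so it remains open whether an amine, a carboxylic acid or a longer chain there would lie closer to compound 3 or to compound 4. Going by these compounds, compound 1 and compound 2 differ from compound 3 in more than one place, so what lifts their numbers also stays open.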